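Cytotoxicity notes: aryl replacement on the shared core

The compounds below may be only part of what the source reports. "The series", "measured", "known", "first", "only" and "open" are said of these compounds alone.

Compound 1 `Cc1ccccc1CNc1nn(-c2ccc(F)cc2F)cc1CNCCN1CCN(C)CC1`: in an ADME assay on Huh-7 cells (Homo sapiens) for cytotoxicity (a higher number here means that more compound is tolerated, a lower number that less compound is tolerated), compound 1 gives > 20000 nM, which is a limit of the assay.
Compound 2 `COc1ccc(-c2nn(-c3ccc(F)cc3F)cc2CNCCN2CCN(C)CC2)cc1`: in this assay compound 2 gives > 20000 nM, again a limit of the assay.

Compound 2 therefore stands at the assay limit, with no number to place it against anything. The step that the two limits leave unreadable from compound 1 to compound 2 cannot be read, since both of its ends sit at the limit described by the limit of > 20000 nM in this assay, at which 2 of the 2 values shown sit.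

Compound 3 `CN1CCN(CCNCc2cn(-c3ccc(F)cc3F)nc2-c2cccc(N(C)C)c2)CC1` carries the change (3-(dimethylamino)phenyl in place of 4-methoxyphenyl on an aromatic carbon). For the measured compounds named here, the only measured step that bears on this position is the unreadable one from compound 1 to compound 2, so no size or direction can be drawn from it. With both neighbours at the limit, compound 3 is expected to sit there as well, estimated at 20000 nM with a range of 8000 nM to 40000 nM. The expected step of a number no higher from compound 2 to compound 3 (the limit leaves the size open) is estimated as none beyond the scatter.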

Compound 3, half-maximal cytotoxic concentration: > 20000 nM
Compound 3 gave a limit, no number (the forecaster's own chance of this, stated with the estimate: 80%); the middle value lies on the limit itself.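

In this assay compound 3 gives > 20000 nM, again a limit of the assay. No step among compound 1, compound 2 and compound 3 can be read: the limit of > 20000 nM in this assay, at which 3 of the 3 values shown sit.

The compounds shown leave open whether the group on this aromatic carbon affects cytotoxicity at all.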